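The source may hold more compounds than are shown below. What is called first, only, known or untested is meant among the compounds shown, and "the series" means these compounds.

Working notes on the series.

Two compounds of the shared core have been through a functional assay on HEL cells (Homo sapiens) (a lower number here means that less compound is tolerated, a higher number that more compound is tolerated), so far. Compound 1 `O=C1c2ccccc2N(Cc2ccccc2Cl)S(=O)(=O)N1Cc1ccccc1` carries a chloro-substituted benzyl on one ring nitrogen and in this assay compound 1 gives 200000 nM. Compound 2 `O=C(OCOCN1c2ccccc2C(=O)N(Cc2ccccc2)S1(=O)=O)c1ccccc1` replaces that benzyl with a (benzoyloxy)methyl chain, and in this assay compound 2 gives 110000 nM. Going by the values given here, compound 2 holds one of only two numbers measured, and the gap to compound 1, its nearest neighbour, lies within the usual scatter of repeated measurements, so the two compounds cannot be told apart on cytotoxicity with what is in hand.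

Compound 3 `C#CCOCN1c2ccccc2C(=O)N(Cc2ccccc2)S1(=O)=O` is the next member and has not yet been through this assay. It differs from compound 2 in one place: ethynyl in place of benzoyloxy on a saturated chain carbon bound to an oxygen on a saturated carbon. Among the compounds with values here, no step between two measured compounds is available for comparison, so there is nothing on which to base a directional expectation for this change.

Given that both measured compounds sit close together, the expectation for compound 3 is a step no larger than the scatter, a 1.2-fold higher number from compound 2 to compound 3 (0.07 log units; within the scatter), in no particular direction. The estimate for compound 3 in this assay is 130000 nM, with a range from 50000 nM to 300000 nM.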

Compound 3, minimum cytotoxic concentration: 140000 nM
Compound 3: middle estimate off by 1.1-fold (0.03 log units), on the low side; the measured number falls inside the stated range.
By their numbers in this assay, from the lowest: compounds 2, 3 and 1 (each within the scatter of the next).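

In this assay, going by these compounds alone, ethynyl in place of benzoyloxy on a saturated chain carbon bound to an oxygen on a saturated carbon gives a 1.3-fold higher number from compound 2 to compound 3 (0.10 log units; within the scatter) and so gives the first step that can be read at this position: a group of 9 heavy atoms with a six-membered aromatic ring gives way to one of 2 heavy atoms with no ring, and the two compounds cannot be told apart. Propargyloxy in place of 2-chlorophenyl on a saturated chain carbon bound to a sulfonamide nitrogen in a ring gives a 1.4-fold lower number from compound 1 to compound 3 (0.15 log units; within the scatter) and also stays inside the usual scatter, so compound 1, compound 2 and compound 3 form one group on minimum cytotoxic concentration. No supporting measurement is at hand to explain this result.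

The compounds shown leave open whether this flat picture holds for a primary amine or a carboxylic acid on the same saturated chain carbon. They also leave open whether a longer chain ending in ethynyl stays with this group in this assay or moves beyond the scatter.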